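Replacing the Ethyl Ether with a Tetramethylpiperidinyl Ether

The source may report more compounds than this note shows. Statements on the series, on what has been measured and on what is new or still open speak of the compounds shown alone.

Compound 3 `CCOc1nc(-c2ccc(NS(=O)(=O)c3cc(Cl)ccc3F)cc2)nc2[nH]nc(C)c12` gives 23 nM in an assay for inhibition of serine/threonine-protein kinase Sgk1 (Homo sapiens), with stated times of 30 min and 60 min, in the presence of a further agent that is not named here (a lower number here means a stronger inhibitor, a higher number a weaker inhibitor), the highest of the two plain numbers shown. Compound 1 `O=C(NC1CCN(C2CC2)C1)c1cc(-c2ccc(NS(=O)(=O)c3cccc(Cl)c3Cl)cc2)nc2[nH]ncc12` gives 6 nM in this assay. Compound 2 `CN1CC(NC(=O)c2cc(-c3ccc(NS(=O)(=O)c4cccc(Cl)c4Cl)cc3)nc3[nH]ncc23)C1` reaches the limit of < 1 nM in this assay, which is a limit and not a number (the limit of < 1 nM in this assay, at which 1 of the 3 values shown sits). The step of an at least 6.0-fold lower number from compound 1 to compound 2 (0.77 log units; beyond the scatter) alters a group on an amide-type nitrogen, a different place from the change studied here. Compound 4 `Cc1n[nH]c2nc(-c3ccc(NS(=O)(=O)c4cc(Cl)ccc4F)cc3)nc(OC3CC(C)(C)NC(C)(C)C3)c12` differs from compound 3 at an oxygen on an aromatic ring: 2,2,6,6-tetramethylpiperidin-4-yl in place of ethyl on an oxygen on an aromatic ring. For the measured compounds named here, no measured step touches that oxygen, so nothing here anchors the direction of the step. Compound 4 is expected to give about 15 nM, within 3 nM to 80 nM, meaning an estimated step of a 1.5-fold lower number from compound 3 to compound 4 (0.19 log units; within the scatter).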

Compound 4, half-maximal inhibitory concentration: 3 nM
Beside the measured number, compound 4's estimate is 5.0-fold (0.70 log units) above it; measured number inside the range.
By their numbers in this assay, from the lowest: compounds 4 and 1 (each within the scatter of the next); then compound 3. At a limit, below all of these: compound 2.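

Swapping ethyl for 2,2,6,6-tetramethylpiperidin-4-yl on this oxygen gives a 7.7-fold lower number from compound 3 to compound 4 (0.88 log units; beyond the scatter) in this assay. For the compounds shown here, this is the first look at this position, and it shows that a much larger group, with 10 heavy atoms, a six-membered ring and a nitrogen, is accepted there, with the number falling rather than rising.

Going by these compounds, with only these two groups on the oxygen, it stays open whether the ring nitrogen or the four methyl groups matter; a plain piperidin-4-yl or a cyclohexyl would separate the two. No measurement shown gives a reason for the step.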